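The source may hold more compounds than are shown below. What is called first, only, known or untested is meant among the compounds shown, and "the series" means these compounds.

Compound 1, `Cc1ccc(Oc2ccc3nc(COc4cccc(C(=O)O)c4)n(C)c3n2)cc1`: 12.6 10^-6 cm/s
Compound 2, `Cc1ccc(Oc2ccc3nc(COc4cccc(C(=O)O)c4)n(C)c3n2)cc1F`: 14.8 10^-6 cm/s

In an ADME assay for permeability, using PAMPA, with a stated time of 4 h (on this read-out higher numbers stand for higher permeability and lower numbers for lower permeability), compound 2 and compound 1 sit within the scatter of each other, the step being a 1.2-fold higher number from compound 1 to compound 2 (0.07 log units; within the scatter). Compound 3, `Cc1cc(C)cc(Oc2ccc3nc(COc4cccc(C(=O)O)c4)n(C)c3n2)c1`, has not been measured. It differs from compound 2 by 3,5-dimethylphenyl in place of 3-fluoro-4-methylphenyl on an oxygen on an aromatic ring. Going by the values given here, the one measured step, a 1.2-fold higher number from compound 1 to compound 2 (0.07 log units; within the scatter), brought a fluorine onto the same ring and changed nothing beyond the scatter; compound 3 loses that fluorine and gains a methyl, so no step beyond the scatter is expected, namely a 1.1-fold lower number from compound 2 to compound 3 (0.06 log units; within the scatter). Compound 3 is therefore estimated at 13 10^-6 cm/s, within 7 10^-6 cm/s to 25 10^-6 cm/s.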

Compound 3, apparent permeability: 17.4 10^-6 cm/s
The estimate for compound 3 lay 1.3-fold (0.13 log units) below the measured number; the range from low to high includes it.
By their numbers in this assay, from the lowest: compounds 1, 2 and 3 (each within the scatter of the next).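

In this assay, 3,5-dimethylphenyl in place of 3-fluoro-4-methylphenyl gives a 1.2-fold higher number from compound 2 to compound 3 (0.07 log units; within the scatter) and, in place of 4-methylphenyl, gives a 1.4-fold higher number from compound 1 to compound 3 (0.14 log units; within the scatter) on the same oxygen. A second methyl on this ring therefore leaves the read-out within the scatter, as fluoro did, and all three compounds remain within the scatter of one another. Nothing available here gives a reason for this result. From the compounds shown here alone, whether an amine or a longer chain on this ring would take the number beyond the scatter stays open.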